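Removing a methoxy group from a bis-amidine-bearing scaffold

The source may report more compounds than this note shows. Statements on the series, on what has been measured and on what is new or still open speak of the compounds shown alone.

Of the compounds shown here, three with an amidine end group have been measured in a functional assay on SF-539 cells (Homo sapiens) for inhibition, read by sulforhodamine B assay, with a stated time of 48 h; a lower number here means a stronger inhibitor of growth, a higher number a weaker inhibitor of growth. Compound 1, whose structure is `COc1ccc(-c2ccc(-c3ccc(C(=N)N)o3)o2)cc1`, gives 1890 nM. Compound 3, with structure `COc1cc(OC)cc(-c2ccc(-c3ccc(C(=N)N)o3)o2)c1`, gives 1830 nM, and compound 2, with structure `N=C(N)c1ccc(-c2ccc(-c3cncc4ccccc34)s2)s1`, gives 1730 nM. Compound 1 therefore sits alongside compounds 3 and 2, with all three numbers falling within the usual scatter of repeated measurements, so none of them can be separated from the others on these data.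

Compound 4, with structure `N=C(N)c1ccc(-c2ccc(-c3ccccc3)o2)o1`, has not yet been measured in this assay. It differs from compound 1 in one place: hydrogen in place of methoxy on an aromatic carbon. Among the measured compounds shown here, no measured pair shows what such a change does on this shared core, so the expectation rests on the narrow spread among compounds 1, 2 and 3 alone. Since the different outer groups in those three compounds gave nearly the same numbers, the step from compound 1 to compound 4 is expected to be small, a 1.2-fold higher number from compound 1 to compound 4 (0.07 log units; within the scatter), and may not exceed the scatter. Compound 4 is accordingly estimated at 2200 nM, within a range from 900 nM to 5500 nM.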

Compound 4, concentration for 50% growth inhibition: 1950 nM
Beside the measured number, compound 4's estimate is 1.1-fold (0.05 log units) above it; low and high end bracket the measured number.
By their numbers in this assay, from the lowest: compounds 2, 3, 1 and 4 (each within the scatter of the next).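

In this assay, putting hydrogen in place of methoxy on an aromatic carbon, para to a large group, gives a 1.0-fold higher number from compound 1 to compound 4 (0.01 log units; within the scatter), so compound 1 and compound 4 cannot be told apart. Among the compounds shown here, this pair gives the first direct reading of a single change on this shared core, whereas the earlier compounds differed from one another in more than one place; here, the methoxy group is not needed to keep the growth-inhibition number where it stands. Nothing measured here offers a reason for this result.

As far as these compounds go, whether the number would also hold with a different group at this place, such as a hydroxyl group, a chlorine atom or an amine, stays open. So does whether the same swap would behave alike on the core of compound 2.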